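The source may hold more compounds than are shown below. What is called first, only, known or untested is meant among the compounds shown, and "the series" means these compounds.

Measured so far:
Compound 1 `Cc1ccccc1Nc1nc(NCc2ccco2)ncc1Cl` — in a functional assay on Jurkat cells (Homo sapiens) for inhibition, read by CCK-8 assay, with a stated time of 48 h (on this read-out lower numbers stand for stronger inhibition of growth and higher numbers for weaker inhibition of growth), compound 1 reaches only a limit of the assay, > 100000 nM.
Compound 2 `Cc1ccc(CNc2nc(Nc3ccc(N4CCN(C)CC4)cn3)ncc2Cl)cc1` — in this assay compound 2 gives 12700 nM.

Within the data shown here, compound 2 thus stands as the only actual number recorded here; the other entry is a limit rather than a number (the limit of > 100000 nM in this assay, at which 1 of the 2 values shown sits). Among the measured compounds shown here, compound 1 and compound 2 differ in more than one place, so their two values show only that one gave a number and the other a limit. Compound 3 `CC(C)c1ccccc1Nc1nc(Nc2ccc(N3CCN(C)CC3)cn2)ncc1Cl` is not yet measured. It differs from compound 2 in one place: 2-isopropylphenyl in place of 4-methylbenzyl on a nitrogen on an aromatic ring. For the measured compounds named here, no measured pair shows this change on its own, so no measured step tells its size. The expected step is a 2.1-fold lower number from compound 2 to compound 3 (0.33 log units; beyond the scatter) in this assay, leaning toward somewhat stronger inhibition, though the range also allows no change beyond the scatter. Compound 3 is therefore estimated at 6000 nM, between 1500 nM and 30000 nM.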

Compound 3, concentration for 50% growth inhibition: 5140 nM
The estimate for compound 3 lay 1.2-fold (0.07 log units) above the measured number; low and high end bracket the measured number.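

Among these compounds, this is the first measured step at this position on the shared core. In this assay, placing 2-isopropylphenyl on the nitrogen instead of 4-methylbenzyl gives a 2.5-fold lower number from compound 2 to compound 3 (0.39 log units; beyond the scatter), so growth inhibition becomes modestly stronger with this exchange, although the two groups differ by only one carbon and each holds one six-membered aromatic ring of carbon only. Nothing measured here explains why the number falls.

The exchange alters two things at once, benzyl becoming phenyl and 4-methyl becoming 2-isopropyl, and the compounds shown do not separate these two parts. Also open, on these data alone, is how an unsubstituted phenyl, or a phenyl carrying an amine or a carboxylic acid, would behave at this position in this assay.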